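The source may report more compounds than this note shows. Statements on the series, on what has been measured and on what is new or still open speak of the compounds shown alone.

Among the measured compounds shown here, in a functional assay on COLO 205 cells (Homo sapiens) for cytotoxicity, read by MTT assay, with a stated time of 72 h (on this read-out higher numbers stand for weaker inhibition and lower numbers for stronger inhibition), compound 2 `C#CCOc1cccc(/C=C/C(=O)Nc2cc(C(=O)c3cc(OC)c(OC)c(OC)c3)ccc2OC)c1` gives 13400 nM; the only comparison is compound 1 `COc1ccc(/C=C/C(=O)Nc2cc(C(=O)c3cc(OC)c(OC)c(OC)c3)ccc2OC)cc1`, which in this assay gives 10900 nM, and the two sit within the scatter of one another, as the step of a 1.2-fold higher number from compound 1 to compound 2 (0.09 log units; within the scatter) shows. Compound 3 `COc1ccc(C(=O)c2cc(OC)c(OC)c(OC)c2)cc1NC(=O)/C=C/c1ccc(N)cc1` differs from compound 2 by 4-aminophenyl in place of 3-(propargyloxy)phenyl on a double-bonded chain carbon bound to a double-bonded chain carbon. For the measured compounds named here, no measured step puts a 4-aminophenyl at this place; the single step available stays within the scatter, so for compound 3 no step beyond the scatter is expected, a 1.3-fold lower number from compound 2 to compound 3 (0.13 log units; within the scatter). Compound 3 is estimated at 10000 nM, with a range from 3500 nM to 30000 nM.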

Compound 3, half-maximal inhibitory concentration: 10300 nM
For compound 3 the middle estimate is 1.0-fold (0.01 log units) below the measured one; measured number inside the range.
By their numbers in this assay, from the lowest: compounds 3, 1 and 2 (each within the scatter of the next).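

In this assay the 4-aminophenyl on a double-bonded chain carbon bound to a double-bonded chain carbon stays within the scatter of the 3-(propargyloxy)phenyl (a 1.3-fold lower number from compound 2 to compound 3 (0.11 log units; within the scatter)). Amino in place of methoxy on an aromatic carbon also stays within the scatter (a 1.1-fold lower number from compound 1 to compound 3 (0.02 log units; within the scatter)), so the first hydrogen-bond donor on this aryl group brings no step beyond the scatter. Nothing at hand accounts for these results.

Still open, going by these compounds, is whether any group at this place gives a step beyond the scatter. A carboxylic acid or a dimethylamino group in place of the amino would test this.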